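A Nitro Group Enters Where Two Methoxy Groups Leave

The source may report more compounds than this note shows. Statements on the series, on what has been measured and on what is new or still open speak of the compounds shown alone.

Three measured compounds share one core and differ only in the aromatic ring at the far end of the chain. Compound 1 `O=C(CN1CCN(c2cc3c(cc2F)c(=O)c(C(=O)O)cn3C2CC2)CC1)Nc1ccc(C(=O)/C=C/c2ccccc2Cl)cc1` carries a 2-chlorophenyl there; in a physicochemical assay for lipophilicity, using the shake flask method, in phosphate buffer, measured as octanol-water partition, with a stated time of 5 h (a lower number here means a more polar compound, a higher number a more lipophilic compound), compound 1 gives 1.29. Compound 2 `O=C(CN1CCN(c2cc3c(cc2F)c(=O)c(C(=O)O)cn3C2CC2)CC1)Nc1ccc(C(=O)/C=C/c2cccc(Cl)c2)cc1` carries a 3-chlorophenyl, and compound 2 gives 0.302. Compound 3 `COc1ccc(/C=C/C(=O)c2ccc(NC(=O)CN3CCN(c4cc5c(cc4F)c(=O)c(C(=O)O)cn5C4CC4)CC3)cc2)cc1OC` carries a 3,4-dimethoxyphenyl, and compound 3 gives 1.46, the highest of the three numbers. Compound 1 lies close to it, within the scatter, while compound 2 stands well apart: a number 1.16 log units higher from compound 2 to compound 3 (beyond the scatter), and a number 0.17 log units higher from compound 1 to compound 3 (within the scatter).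

Compound 4 `O=C(CN1CCN(c2cc3c(cc2F)c(=O)c(C(=O)O)cn3C2CC2)CC1)Nc1ccc(C(=O)/C=C/c2cccc([N+](=O)[O-])c2)cc1` has not yet been measured. The change from compound 3 is 3-nitrophenyl in place of 3,4-dimethoxyphenyl on a double-bonded chain carbon bound to a double-bonded chain carbon. Going by the values given here, no measured step involves a 3-nitrophenyl, so the only guides are the exchanges among the three rings already seen. a number 0.99 log units lower from compound 1 to compound 2 (beyond the scatter) and a number 1.16 log units higher from compound 2 to compound 3 (beyond the scatter) show that swapping this ring can move the number a long way in either direction, whereas a number 0.17 log units higher from compound 1 to compound 3 (within the scatter) shows that such a swap can also stay within the scatter. With the 3-nitrophenyl untested, the expected step is placed between these outcomes, leaning to the lower side: compound 4 is expected to show a number 0.76 log units lower from compound 3 to compound 4 (beyond the scatter). The estimated value for compound 4 is 0.7, with a range from 0.1 to 1.4.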

Compound 4, partition coefficient: -0.0812
Beside the measured number, compound 4's estimate is 0.78 log units above it; the measured number lies below the stated range.
By their numbers in this assay, from the lowest: compound 4; then compound 2; then compounds 1 and 3 (each within the scatter of the next).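

In this assay, compound 4 gives -0.0812, and its steps to all three earlier compounds lie beyond the scatter, making it the lowest of the four. Exchanging the whole ring produces a number 1.54 log units lower from compound 3 to compound 4 (beyond the scatter) and a number 1.37 log units lower from compound 1 to compound 4 (beyond the scatter), both large steps, so this position can carry the number below the range set by the three earlier rings. The closest comparison is nitro in place of chloro on an aromatic carbon, which leaves the rest of the molecule unchanged and still gives a number 0.38 log units lower from compound 2 to compound 4 (beyond the scatter), a modest step showing that the identity of this single group on the ring matters; no evidence is available to explain any of these differences.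

The compounds shown leave open whether a nitrile or an amine in place of the nitro group would give a number as low as that of compound 4. They also leave open whether a 2-nitrophenyl would differ from the 3-nitrophenyl as strongly as the 2-chlorophenyl of compound 1 differs from the 3-chlorophenyl of compound 2.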